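Swapping the butyl arm for a pyridylmethyl arm

The source may hold more compounds than are shown below. What is called first, only, known or untested is meant among the compounds shown, and "the series" means these compounds.

Measured compounds:
compound 1 `Cc1cccc(CSc2nc3cc(NC(=O)C4CC4)ccc3n2C(C)C)c1` 6500 nM
compound 2 `COc1ccccc1CSc1nc2cc(NC(=O)C3CC3)ccc2n1C(C)C` 2100 nM
compound 3 `CCCCn1c(SCc2cc([N+](=O)[O-])ccc2OC)nc2cc(NC(=O)NC(C)(C)C)ccc21` 23 nM

In an assay on isolated protein for inhibition of Gonadotropin-releasing hormone receptor (Homo sapiens) (a higher number here means a weaker inhibitor, a lower number a stronger inhibitor), compound 3 stands lowest of the three numbers; compound 2 and compound 1 stand well above it, both beyond the scatter. Compound 4 `COc1ccc([N+](=O)[O-])cc1CSc1nc2cc(NC(=O)NC(C)(C)C)ccc2n1Cc1cccnc1` keeps the core of compound 3 and differs in one place: pyridin-3-yl in place of propyl on a saturated chain carbon bound to an aromatic nitrogen.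

Within the data shown here, the only measured single step, a 3.1-fold lower number from compound 1 to compound 2 (0.49 log units; beyond the scatter), concerns the group on the saturated chain carbon bound to sulfur, a different place from the one changed here. Among the measured compounds shown here, compound 3 also differs from compound 2 in several places at once, so no step separates what the group on the aromatic nitrogen contributes. Nothing measured therefore bears directly on this change. The expectation is for compound 4 to stay near compound 3, with a step of a 1.3-fold higher number from compound 3 to compound 4 (0.12 log units; within the scatter) that is not expected to go beyond the scatter in either direction. Compound 4 is estimated at 30 nM, within a range of 10 nM to 100 nM.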

Compound 4, half-maximal inhibitory concentration: 33 nM
The estimate for compound 4 lay 1.1-fold (0.04 log units) below the measured number; low and high end bracket the measured number.
By their numbers in this assay, from the lowest: compounds 3 and 4 (each within the scatter of the next); then compound 2; then compound 1.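

In this assay, putting pyridin-3-yl in place of propyl on the saturated chain carbon bound to an aromatic nitrogen gives a 1.4-fold higher number from compound 3 to compound 4 (0.16 log units; within the scatter), so the two compounds cannot be told apart. This is the first single change shown at this place, and it shows that the number can hold even when the group gains heavy atoms, an aromatic ring and a hydrogen-bond acceptor. Nothing measured on these compounds explains why the number holds.

The compounds shown leave open whether the ring nitrogen of pyridin-3-yl matters, which a plain phenyl ring at the same place would address. They also leave open how far this place accepts other groups, such as an amine, a carboxylic acid or a longer chain.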